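A few compounds are considered here, and "the series" means these few. Any claim that something is new, unique, unknown or untested is made for them only; others in the source may bear on it.

Measured compounds:
compound 1 `Cc1nc(N)sc1CCCN/C(N)=N/C(=O)N[C@H](C)c1ccccc1` — 0.95
compound 2 `Cc1ccc(C(C)NC(=O)/N=C(\N)NCCCc2sc(N)nc2C)cc1` — 0.85

Both numbers come from a functional assay on Right cardiac atrium for agonist activity at histamine H2 receptor (Cavia porcellus), with a stated time of 30 min, in the presence of a further agent that is not named here; on this read-out lower numbers stand for smaller maximal responses and higher numbers for larger maximal responses. Compound 1 gives 0.95 there, and compound 2 gives 0.85. Compound 2 has the lower of the two numbers, but its gap to compound 1 lies within the usual scatter, so the two cannot be ordered. Compound 3 `Cc1nc(N)sc1CCCN/C(N)=N/C(=O)NC(C)c1ccco1` has not yet been measured. Relative to compound 2 it shows (furan-2-yl in place of 4-methylphenyl on a saturated chain carbon bound to an amide-type nitrogen and a saturated chain carbon). Among the measured compounds shown here, no measured pair differing in only one place exists here, so the size of such a step is not known from these data. Because compound 2 gives 0.85 and compound 1 gives 0.95, compound 3 is expected to keep a large maximal response, and the step is estimated at a number 0.030 higher from compound 2 to compound 3 (within the scatter), not expected to go beyond the scatter in either direction. Compound 3 is therefore estimated at 0.88, with a range from 0.72 to 1.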

Compound 3, intrinsic activity: the largest response reached, as a fraction of the reference agonist's: 1
For compound 3 the middle estimate is 0.12 below the measured one, within the range that was stated.
By their numbers in this assay, from the lowest: compounds 2, 1 and 3 (each within the scatter of the next, the first and the last beyond it).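

Putting furan-2-yl in place of 4-methylphenyl on a saturated chain carbon bound to an amide-type nitrogen and a saturated chain carbon gives a number 0.15 higher from compound 2 to compound 3 (beyond the scatter) in this assay and so provides the first difference at this position that exceeds the scatter. Set against the 1-phenylethyl group, however, the 1-(furan-2-yl)ethyl group gives a number 0.050 higher from compound 1 to compound 3 (within the scatter) and so cannot be ordered against it. The data offer no explanation for either step.

The compounds shown leave open whether a large maximal response at this position depends on the furan-2-yl group in particular, or whether thiophen-2-yl or pyridin-2-yl would do the same. They also leave open how far the response would fall with an aromatic group bearing a larger substituent than methyl, such as 4-methoxyphenyl.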